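Removing the Chloro From a Furan Hydroxamic Acid

The compounds below may be only part of what the source reports. "The series", "measured", "known", "first", "only" and "open" are said of these compounds alone.

Compound 1 `O=C(/C=C/c1ccc(/C=C/C(=O)c2ccc(Cl)cc2)o1)NO`: 6740 nM
Compound 2 `COc1ccc2cc(C(=O)/C=C/c3ccc(/C=C/C(=O)NO)o3)ccc2c1`: 6220 nM

In a functional assay on HepG2 cells (Homo sapiens) for antiproliferative activity, read by MTT assay, with a stated time of 48 h (on this read-out higher numbers stand for weaker inhibition and lower numbers for stronger inhibition), compound 1 gives 6740 nM, the higher of the two numbers, although its gap to compound 2, which gives 6220 nM, lies within the scatter. As far as these compounds go, compound 3 `O=C(/C=C/c1ccc(/C=C/C(=O)c2ccccc2)o1)NO` is untested. It differs from compound 1 in one place: hydrogen in place of chloro on an aromatic carbon. Going by the values given here, no measured pair shows this change, so no step can be drawn on. Because compound 1 gives 6740 nM and the change is a single heavy atom replaced by hydrogen, only a small shift is expected. Compound 3 is estimated at 8500 nM, within 3500 nM to 20000 nM. The expected step of a 1.3-fold higher number from compound 1 to compound 3 (0.10 log units; within the scatter) is small, toward a slightly higher number.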

Compound 3, half-maximal inhibitory concentration: 12100 nM
The estimate for compound 3 lay 1.4-fold (0.15 log units) below the measured number; measured number inside the range.
By their numbers in this assay, from the lowest: compounds 2, 1 and 3 (each within the scatter of the next).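

In this assay, going by these compounds alone, hydrogen in place of chloro on this aromatic carbon gives a 1.8-fold higher number from compound 1 to compound 3 (0.25 log units; within the scatter) and so offers the first direct look at this position. Going from 4-chlorophenyl to phenyl leaves compound 3 indistinguishable from compound 1 on this read-out, so the chloro shows no measurable contribution here. Nothing measured on these compounds bears on why this is so. As far as these compounds go, whether an amine or a carboxylic acid on the same carbon would give a number beyond the scatter remains open. So does whether the same holds on another core.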